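A few compounds are considered here, and "the series" means these few. Any claim that something is new, unique, unknown or untested is made for them only; others in the source may bear on it.

Working notes on the series. In a functional assay on HT-29 cells (Homo sapiens) for cytotoxicity (a lower number here means that less compound is needed, a higher number that more compound is needed for the effect), compound 1 `COc1cc(/C=C/c2ccc(C(C)C)cc2)cc(OC)c1OC` gives 6.8 uM, and compound 2 `COc1cc(/C=C/c2ccc(SC)cc2)cc(OC)c1OC` gives 8.3 uM. For the measured compounds named here, the one step available, a 1.2-fold higher number from compound 1 to compound 2 (0.09 log units; within the scatter), stays inside the scatter. Compound 3 `CCOc1ccc(/C=C\c2cc(OC)c(OC)c(OC)c2)cc1` gives 1.8 uM in this assay, the lowest of the three numbers; its gap to compound 1 and its gap to compound 2 both lie beyond the scatter, so compound 3 stands apart from the other two.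

The next compound, compound 4 `CCOc1ccc(/C=C/c2cc(OC)c(OC)c(OC)c2)cc1`, has not been measured. It differs from compound 3 as follows: the two compounds have the same atoms and bonds and differ only in configuration as drawn: 1 of 1 stereo elements differ; a double bond is drawn Z in compound 3 and E in compound 4. Going by the values given here, no measured step concerns a change of double-bond geometry; the only step, from compound 1 to compound 2, swaps one substituent on an aromatic carbon and says nothing about configuration. Among the compounds with values here, what can be noted is that compound 1 and compound 2 are drawn with the E configuration and give higher numbers than compound 3, though no single-change step connects them to compound 3.

Within the data shown here, with no directly relevant step, the expectation for compound 4 rests on that observation alone: the number is expected to rise, with a 5.6-fold higher number from compound 3 to compound 4 (0.74 log units; beyond the scatter) as the estimated step, and a wide range. The estimate for compound 4 in this assay is 10 uM, between 3 uM and 40 uM.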

Compound 4, concentration for half-maximal effect: 1.49 uM
The estimate for compound 4 lay 6.7-fold (0.83 log units) above the measured number, and the stated range ends above it.
By their numbers in this assay, from the lowest: compounds 4 and 3 (each within the scatter of the next); then compounds 1 and 2 (each within the scatter of the next).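

In this assay, the double-bond change gives a 1.2-fold lower number from compound 3 to compound 4 (0.08 log units; within the scatter), so the two geometries cannot be told apart in this read-out, a point no earlier step could address, and the comparison concerns geometry alone: the fact that compounds 3 and 4 differ only in the configuration as drawn

Compound 4 also links the ethoxy compounds to the E-drawn compounds through single changes on an aromatic carbon: ethoxy in place of methylsulfanyl gives a 5.6-fold lower number from compound 2 to compound 4 (0.75 log units; beyond the scatter), and ethoxy in place of isopropyl gives a 4.6-fold lower number from compound 1 to compound 4 (0.66 log units; beyond the scatter). Both steps lie beyond the scatter, whereas a 1.2-fold higher number from compound 1 to compound 2 (0.09 log units; within the scatter) does not, so within these E-drawn compounds the separation appears with ethoxy at this place and does not depend on a change of geometry.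

For the compounds shown here, whether geometry is equally silent with other substituents remains open, since the only Z-drawn compound here carries ethoxy, and Z partners of compound 1 and compound 2 would be needed to test this. Going by these compounds, it also remains open how a methoxy group, a longer propoxy chain or an amine would read at the place held by ethoxy, and hence whether ethoxy is a particular case or part of a wider trend.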